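This account rests on a few compounds, and the source may have more. Where it says the series, first, only, none or still open, it means among the compounds named here.

In a functional assay on MCF7 cells (Homo sapiens) for inhibition, read by MTT assay, with a stated time of 72 h (a higher number here means a weaker inhibitor, a lower number a stronger inhibitor), the series so far reads:
compound 1 `O=[N+]([O-])c1ccc(-c2nnc(SCCCN3CCN(c4nc5ccccc5o4)CC3)o2)cc1` gives 90100 nM
compound 2 `Cc1ccc(-c2nnc(SCCCN3CCN(c4nc5ccccc5o4)CC3)o2)cc1` gives 60400 nM
compound 3 `Brc1ccc(-c2nnc(SCCCN3CCN(c4nc5ccccc5o4)CC3)o2)cc1` gives 115000 nM

Compound 3 cannot be separated from the other two measured compounds. The data show a 1.3-fold higher number from compound 1 to compound 3 (0.11 log units; within the scatter) and also a 1.9-fold higher number from compound 2 to compound 3 (0.28 log units; within the scatter) for this comparison.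

The next compound is compound 4 `Oc1ccc(-c2nnc(SCCCN3CCN(c4nc5ccccc5o4)CC3)o2)cc1`, and the change is hydroxy in place of bromo on an aromatic carbon in the form of hydroxy in place of bromo on an aromatic carbon, para to a large group.

The measured steps that bear on this place are the swaps among nitro, methyl and bromo. Besides the two above, there is a 1.5-fold lower number from compound 1 to compound 2 (0.17 log units; within the scatter) as the third of them, and none of the three leaves the scatter. Within the data shown here, no measured compound carries hydroxy, so this expectation reaches past the substituents tested, and the range is kept wide.

Going by a 1.9-fold higher number from compound 2 to compound 3 (0.28 log units; within the scatter) and the other two steps, no step beyond the scatter is expected in this assay for this change. The expected size of the change is a 1.4-fold lower number from compound 3 to compound 4 (0.16 log units; within the scatter) on this estimate. For compound 4 the estimated value is 80000 nM with an expected range from 30000 nM to 200000 nM in this read-out.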

Compound 4, half-maximal inhibitory concentration: 260000 nM
For compound 4 the middle estimate is 3.3-fold (0.51 log units) below the measured one, and the stated range ends below it.
By their numbers in this assay, from the lowest: compounds 2, 1 and 3 (each within the scatter of the next); then compound 4.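

In this assay, among these compounds, hydroxy on this aromatic carbon, para to a large group, is the first substituent to separate from the others, with all three steps beyond the scatter (a 2.3-fold higher number from compound 3 to compound 4 (0.35 log units; beyond the scatter); a 4.3-fold higher number from compound 2 to compound 4 (0.63 log units; beyond the scatter); a 2.9-fold higher number from compound 1 to compound 4 (0.46 log units; beyond the scatter)). Nitro, methyl and bromo could not be told apart at this position, so the place is not indifferent to every substituent, and compound 4 is the weakest of the four, though the steps remain modest. The swap from bromo to hydroxy adds a hydrogen-bond donor and a hydrogen-bond acceptor by count, but no measurement here accounts for the step.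

Open, from the compounds shown here alone, is whether the step belongs to hydroxy alone or extends to other groups at this place, such as methoxy, an amine or a carboxylic acid. Also open is whether any group on this aromatic carbon can move the number below the level shared by compounds 1, 2 and 3, since none of the substituents shown does so.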